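This account rests on a few compounds, and the source may have more. Where it says the series, first, only, none or still open, it means among the compounds named here.

In a functional assay on HL-60 cells (Homo sapiens) for inhibition, read by MTT assay, with a stated time of 72 h (on this read-out higher numbers stand for weaker inhibition and lower numbers for stronger inhibition), compound 1 (`Cc1nc(-c2cccc(F)c2)c(C(=O)N2CCN(c3cccc(Cl)c3)CC2)o1`) gives 33.7 nM and compound 2 (`CC(=O)Nc1cccc(-c2nc(C)oc2C(=O)N2CCN(c3cccc(Cl)c3)CC2)c1`) gives 208 nM, which is the higher of the two numbers. Compound 3 (`Cc1nc(-c2cccc(OP(=O)(O)O)c2)c(C(=O)N2CCN(c3cccc(Cl)c3)CC2)o1`) differs from compound 2 on an aromatic carbon, meta to a large group (a group of 5 heavy atoms (4 oxygen, 1 phosphorus; no ring) in place of a group of 4 heavy atoms (2 carbon, 1 nitrogen, 1 oxygen; no ring), on an aromatic carbon). Within the data shown here, only one measured step bears on this place, namely a 6.2-fold higher number from compound 1 to compound 2 (0.79 log units; beyond the scatter) for acetamido in place of fluoro. That single step gives no direction for the new group, so no change beyond the scatter is expected, though one of similar size remains possible. The estimated step is a 1.2-fold higher number from compound 2 to compound 3 (0.08 log units; within the scatter) in this assay as the central expectation. Compound 3 is expected at 250 nM (40 nM to 1200 nM).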

Compound 3, half-maximal inhibitory concentration: > 1000 nM
Compound 3: a limit, no number (the forecaster's own chance of this, stated with the estimate: 5%); middle value at least 4.0-fold (0.60 log units) from the limit.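

In this assay compound 3 is a limit and not a number: the limit of > 1000 nM in this assay, at which 1 of the 3 values shown sits. At this aromatic carbon, meta to a large group, the group of 5 heavy atoms (4 oxygen, 1 phosphorus) gives an at least 4.8-fold higher number from compound 2 to compound 3 (0.68 log units; beyond the scatter) and an at least 29-fold higher number from compound 1 to compound 3 (1.47 log units; beyond the scatter). Among these compounds, the single earlier step gave no direction for a new group, whereas the three compounds now rank fluoro, acetamido and this group in order of weakening inhibition.

As far as these compounds go, how far compound 3 lies past its limit remains open. So does whether a carboxylic acid, an amine or a methoxy group on the same carbon would read nearer compound 1 or compound 3.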